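A few compounds are considered here, and "the series" means these few. Any claim that something is new, unique, unknown or untested is made for them only; others in the source may bear on it.

Compound 1 `CCOC(=O)C1=C(C)NC(=O)NC1c1cn(-c2ccccc2)nc1-c1ccccc1` gives 60800 nM in a functional assay on MCF7 cells (Homo sapiens) for inhibition, read by sulforhodamine B assay, with a stated time of 24 h (on this read-out higher numbers stand for weaker inhibition of growth and lower numbers for stronger inhibition of growth), the higher of the two numbers recorded so far. Compound 2 `CC1=C(C(=O)Nc2ccc([N+](=O)[O-])cc2)C(c2cn(-c3ccccc3)nc2-c2ccccc2)NC(=O)N1` gives 35500 nM in this assay, and the step of a 1.7-fold lower number from compound 1 to compound 2 (0.23 log units; within the scatter) stays within the scatter, so no order between these two is established. Compound 3 `CCOC(=O)C1=C(C)NC(=O)NC1c1cn(-c2ccccc2)nc1-c1ccc(Cl)cc1` has not yet been measured; it differs from compound 1 by chloro in place of hydrogen on an aromatic carbon. Among the compounds with values here, no measured step bears on this change: the one step available alters the group on a carbonyl carbon and leaves both phenyl rings untouched. Within the data shown here, with no precedent for a change on an aromatic carbon, the working expectation for compound 3 is a number close to that of compound 1, with no step beyond the scatter expected in this assay, namely a 1.4-fold lower number from compound 1 to compound 3 (0.13 log units; within the scatter). Compound 3 is therefore estimated at 45000 nM, within a range from 15000 nM to 150000 nM.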

Compound 3, concentration for 50% growth inhibition: 68800 nM
The estimate for compound 3 lay 1.5-fold (0.18 log units) below the measured number; measured number inside the range.
By their numbers in this assay, from the lowest: compounds 2, 1 and 3 (each within the scatter of the next).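

Chloro in place of hydrogen, para to a large group, gives the series its first reading of a change on an aromatic carbon: in this assay the step is a 1.1-fold higher number from compound 1 to compound 3 (0.05 log units; within the scatter). Phenyl and 4-chlorophenyl therefore cannot be told apart here, and this one-atom change at this position leaves the number within the scatter. No measurement on hand offers an account of this result.

As far as these compounds go, whether an amine, a hydroxyl or a methoxy group at the same place would give a step beyond the scatter remains open, as does the effect of chloro on the other phenyl ring. Also open, from the compounds shown here alone, is whether chloro would give the same step with (4-nitrophenyl)amino in place of ethoxy on the carbonyl carbon.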